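The source may report more compounds than this note shows. Statements on the series, on what has been measured and on what is new or still open speak of the compounds shown alone.

Of the compounds shown here, three sharing a core have been measured in an ADME assay on Ava5 cells (Homo sapiens) for cytotoxicity; on this read-out lower numbers stand for higher toxicity in this test and higher numbers for lower toxicity in this test. Compound 1 (`NC(=S)Nc1cccc(OCCCCCCc2ccccc2)c1`) gives 28000 nM, a measured number. Compound 2 (`COc1ccc(OCCCCCOc2cccc(NC(N)=S)c2)cc1`) gives only a limit of the assay, > 50000 nM. Compound 3 (`NC(=S)Nc1cccc(OCCCCCOc2ccccn2)c1`) also gives a limit and not a number, > 50000 nM. That places compound 3 at the limit of > 50000 nM in this assay, at which 2 of the 3 values shown sit.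

Compound 4 (`NC(=S)Nc1cccc(OCCCCCOc2ccncc2)c1`) has the same atoms as compound 3, joined differently, with pyridin-4-yl in place of pyridin-2-yl on an oxygen on a saturated carbon. Two measured steps lead to compound 3, and neither makes this exchange. The first, with (pyridin-2-yl)oxy in place of benzyl, is an at least 1.7-fold higher number from compound 1 to compound 3 (0.25 log units; that floor lies within the scatter). The second, with pyridin-2-yl in place of 4-methoxyphenyl, is a step that the two limits leave unreadable from compound 2 to compound 3. Neither step therefore gives a size for moving between the two pyridinyl groups, and no step beyond the scatter is expected in this assay. The expected change is a number no higher from compound 3 to compound 4 (the limit leaves the size open). Another limit rather than a number would be no surprise. For compound 4 the estimated value is 50000 nM, with an expected range of 22000 nM to 100000 nM.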

Compound 4, half-maximal cytotoxic concentration: > 50000 nM
Compound 4 was reported as a limit; the forecaster's own chance of this, stated with the estimate: 60%; the middle value sits exactly at the limit.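

In this assay compound 4 gives > 50000 nM, which is a limit of the assay and not a number, so moving to pyridin-4-yl on the oxygen brings no measured value and adds a further compound at that limit: the limit of > 50000 nM in this assay, at which 3 of the 4 values shown sit. The steps from compound 2 and from compound 3 to compound 4 cannot be read, since both ends of each are limits, and the exchange of pyridin-2-yl for pyridin-4-yl therefore has no size here. For the compounds shown here, the one step that can be read is an at least 1.7-fold higher number from compound 1 to compound 4 (0.25 log units; that floor lies within the scatter), and it gives only a floor, so the true size of the step remains unknown.

The compounds shown leave open how far compound 3 and compound 4 lie past the limit, and so whether pyridin-2-yl and pyridin-4-yl differ at all in this test. They also leave open whether a longer chain, or an amine in place of the pyridinyl group, would give a measured number, as among these compounds only compound 1 does, with 28000 nM.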